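Trading Chloro for Methyl on the Fused Core

This account rests on a few compounds, and the source may have more. Where it says the series, first, only, none or still open, it means among the compounds named here.

Compound 2 `Fc1ccc(CNc2nc(Nc3cc(C4CC4)[nH]n3)c3cc(Cl)ccc3n2)c(F)c1` gives 72 nM in an assay for inhibition of high affinity nerve growth factor receptor (Homo sapiens), read by HTRF, with a stated time of 30 min, in the presence of a further agent that is not named here (on this read-out higher numbers stand for weaker inhibition and lower numbers for stronger inhibition), the lowest of the two numbers recorded so far. Going by the values given here, its only measured companion, compound 1 `Cc1cc(Nc2nc(NCc3ccc(F)cc3F)nc3ccc(Cl)cc23)n[nH]1`, gives 520 nM in this assay, and the single measured step, a 7.2-fold lower number from compound 1 to compound 2 (0.86 log units; beyond the scatter), concerns an exchange of groups on an aromatic carbon elsewhere in the molecule, not on the fused core.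

Compound 3 `Cc1ccc2nc(NCc3ccc(F)cc3F)nc(Nc3cc(C4CC4)[nH]n3)c2c1` differs from compound 2 by methyl in place of chloro on an aromatic carbon. Among the compounds with values here, no measured step touches this position: both compound 1 and compound 2 carry chloro there, so the consequence of exchanging it for methyl is untested. Exchanges of one group for another at a single aromatic carbon are frequently modest in size, and the direction cannot be read from the two numbers available. Compound 3 is therefore expected to give 150 nM in this assay, within a range of 40 nM to 600 nM, which amounts to an expected step of a 2.1-fold higher number from compound 2 to compound 3 (0.32 log units; beyond the scatter).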

Compound 3, half-maximal inhibitory concentration: 57 nM
Beside the measured number, compound 3's estimate is 2.6-fold (0.42 log units) above it; the measured number falls inside the stated range.
By their numbers in this assay, from the lowest: compounds 3 and 2 (each within the scatter of the next); then compound 1.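

In this assay, putting methyl in place of chloro on this aromatic carbon gives a 1.3-fold lower number from compound 2 to compound 3 (0.10 log units; within the scatter), so this pair gives no sign that the read-out separates the two groups at this position. Going by these compounds alone, this is the first measured exchange here, as compound 1 and compound 2 both carry chloro at this place; it also contrasts with the only earlier step, a 7.2-fold lower number from compound 1 to compound 2 (0.86 log units; beyond the scatter), which concerns the swap of methyl for cyclopropyl elsewhere in the molecule and lies beyond the scatter. Nothing measured here explains why chloro and methyl read alike at this position.

Chloro and methyl each bring one heavy atom and no ring, so this single pair says little about how a group of a different kind would read at this place, such as an amine, a carboxylic acid, a methoxy group or a longer chain. It also leaves open whether chloro and methyl would still read alike with methyl rather than cyclopropyl on the other aromatic carbon, as in compound 1.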